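A few compounds are considered here, and "the series" means these few. Any claim that something is new, unique, unknown or untested is made for them only; others in the source may bear on it.

Measured so far in an ADME assay on L6 cells (Rattus norvegicus) for cytotoxicity; a higher number here means a weaker inhibitor, a lower number a stronger inhibitor:
- compound 1, `COc1cc(C(=N)NC(C)C)cc2cc(-c3ccc(C(=N)NC(C)C)cc3)oc12`: > 190000 nM
- compound 2, `CC(C)NC(=N)c1ccc(-c2cc3cc(C(=N)NC(C)C)cc(O)c3o2)cc1`: > 185000 nM
- compound 3, `COc1ccc(C(=N)N)cc1-c1cc2ccc(C(=N)N)cc2o1`: 128000 nM.

The value of compound 1 in this assay is a limit, not a number, and the same holds for compound 2. Compound 3 is the only one of the three with a number in this assay. Between compound 1 and compound 2 one change is made: hydrogen in place of methyl on an oxygen on an aromatic ring. Its size is not readable, a step that the two limits leave unreadable from compound 1 to compound 2, since both compounds sit at a limit, as shown by the limit of > 190000 nM in this assay, at which 1 of the 3 values shown sits, and (the limit of > 185000 nM in this assay, at which 1 of the 3 values shown sits).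

Compound 4, `N=C(N)c1ccc(O)c(-c2cc3ccc(C(=N)N)cc3o2)c1`, has not yet been measured in this assay. It differs from compound 3 by hydrogen in place of methyl on an oxygen on an aromatic ring, the same change as from compound 1 to compound 2. How the core of compound 3 differs from the core of compound 1 is not broken down here.

From the change in compound 1 to compound 2 no direction can be read, so the expected step of a 1.2-fold higher number from compound 3 to compound 4 (0.07 log units; within the scatter) for compound 4 is set close to no change and rests on compound 3 giving 128000 nM in this assay. Compound 4 is therefore expected to give about 150000 nM in this assay, with a range from 70000 nM to 320000 nM, and a fair chance that only a limit is reported.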

Compound 4, half-maximal inhibitory concentration: 164000 nM
Compound 4: the middle estimate sits 1.1-fold (0.04 log units) below what was measured; the measured number falls inside the stated range.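

In this assay, going from methoxy to hydroxy on the core of compound 3 gives a 1.3-fold higher number from compound 3 to compound 4 (0.11 log units; within the scatter), so on this core the change leaves the value within the usual scatter of the measurement. On the core of compound 1 the same change cannot be read: compound 1 and compound 2 each give only a limit, not a number. The change therefore has a readable size on one core alone, which shows that it makes no clear difference there but does not show that it would behave the same way on the core of compound 1, or that the two cores respond alike.

On these data alone, it remains open whether a longer chain on that oxygen, such as ethyl or propyl, would move the value beyond the scatter, and whether an amine in place of the hydroxy would do so. Also open, as far as these compounds go, is how the change from methoxy to hydroxy would read on any further core where both partners give numbers.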